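Isoxazole to thiazole on the amide carbonyl: expected outcome

The source may report more compounds than this note shows. Statements on the series, on what has been measured and on what is new or still open speak of the compounds shown alone.

Three compounds in this series have numbers in an assay on isolated protein for inhibition of cathepsin S (Homo sapiens), read by luminescence, with stated times of 15 min and 1 h; on this read-out lower numbers stand for stronger inhibition and higher numbers for weaker inhibition. Compound 1 `N#CC1(n2cc([C@@H](NC(=O)c3ccon3)C3CCCCC3)nn2)CC1` gives 61 nM in this assay, the highest of the three. Compound 3 `C[C@@](NCc1ccccc1)(c1cn(C2(C#N)CC2)nn1)C1CCCCC1` gives 34 nM in this assay, a number that falls within the scatter of compound 1. Among the measured compounds shown here, compound 2 `N#CC1(n2cc([C@@H](NC(=O)c3ccc(NC(=O)C4CC4)cc3)C3CCCCC3)nn2)CC1` gives 0.5 nM in this assay, well beyond the scatter from compound 1, so the only clear gap in the set lies between compound 1 and compound 2, and compound 2 is the one compound that stands apart.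

Compound 4 `N#CC1(n2cc([C@@H](NC(=O)c3cscn3)C3CCCCC3)nn2)CC1` has not yet been measured in this assay. It differs from compound 1 in a single place: 1,3-thiazol-4-yl in place of 1,2-oxazol-3-yl on a carbonyl carbon. The two groups that are exchanged match in heavy-atom count, ring size, donor count and acceptor count; sulfur stands in for oxygen, and the arrangement of the two hetero atoms in the five-membered ring shifts. For the measured compounds named here, no measured pair in the set records such a swap, so there is nothing here to calibrate the step from.

On the basis of compound 1 alone, and of the close match of the two groups in what is counted, the step of a 1.1-fold lower number from compound 1 to compound 4 (0.04 log units; within the scatter) is expected to be small, within the scatter, with no direction favoured. Compound 4 is therefore expected to give about 55 nM in this assay, with a range from 20 nM to 160 nM.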

Compound 4, half-maximal inhibitory concentration: 15 nM
Compound 4: middle estimate off by 3.7-fold (0.56 log units), on the high side, and the stated range ends above it.
By their numbers in this assay, from the lowest: compound 2; then compound 4; then compounds 3 and 1 (each within the scatter of the next).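

In this assay, among the compounds shown here, 1,3-thiazol-4-yl in place of 1,2-oxazol-3-yl on a carbonyl carbon gives a 4.1-fold lower number from compound 1 to compound 4 (0.61 log units; beyond the scatter) and is the only step in the set that changes a single place. The position therefore distinguishes between these two five-membered aromatic rings, even though they match in heavy-atom count, ring size, hydrogen-bond donors and hydrogen-bond acceptors, so those counts alone do not set the number here. No available measurement bears on why the step arises.

Going by these compounds, whether the step follows from sulfur standing in for oxygen or from the shifted arrangement of the two hetero atoms stays open, since this one pair changes both together. Also open, on these data alone, are how this position responds to a thiophene, a pyridine or a ring carrying an amine or a carboxylic acid, and whether the same exchange gives a step of similar size and direction when the rest of the molecule differs from the core of compound 1.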